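Benzylcarbamoyl in place of methoxycarbonyl on the free amine

A few compounds are considered here, and "the series" means these few. Any claim that something is new, unique, unknown or untested is made for them only; others in the source may bear on it.

compound 1 `CC(C)(C)OC(=O)NCCCCCN1C(Nc2ccc(-c3ccccc3)cc2)=Nc2ccccc2C1CC(=O)NCc1ccccc1`: 170 nM
compound 2 `COC(=O)CC1c2ccccc2N=C(Nc2ccc(-c3ccccc3)cc2)N1CCCCCNC(=O)OC(C)(C)C`: 370 nM
compound 3 `COC(=O)CC1c2ccccc2N=C(Nc2ccc(-c3ccccc3)cc2)N1CCCCCN`: 300 nM

In an assay on HEK293 cells for inhibition of Voltage-dependent T-type calcium channel subunit alpha-1G (Homo sapiens) (a higher number here means a weaker inhibitor, a lower number a stronger inhibitor), compound 3 gives the second highest of the three numbers. Its nearest neighbour is compound 2, and that gap is within the scatter; the furthest is compound 1, and that gap is within the scatter too, so on these three numbers compound 3 is not distinguishable from either.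

Compound 4 `NCCCCCN1C(Nc2ccc(-c3ccccc3)cc2)=Nc2ccccc2C1CC(=O)NCc1ccccc1` differs from compound 3 by benzylamino in place of methoxy on a carbonyl carbon. Among the measured compounds shown here, one measured step bears directly on this change: a 2.2-fold higher number from compound 1 to compound 2 (0.34 log units; beyond the scatter), which is the same swap run the other way, on the same carbonyl carbon, with tert-butoxycarbonyl still on the amine nitrogen. The step of a 1.2-fold lower number from compound 2 to compound 3 (0.09 log units; within the scatter) shows that taking that tert-butoxycarbonyl off left the number where it was, so there is no sign in the data that the amine end alters how the ester-to-amide swap reads.

Compound 4 is therefore expected to move in the opposite direction to the ester step, by a 2.1-fold lower number from compound 3 to compound 4 (0.33 log units; beyond the scatter), a modest step just beyond the scatter. The estimate for compound 4 is 140 nM, with a range of 60 nM to 330 nM.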

Compound 4, half-maximal inhibitory concentration: 140 nM
The estimate for compound 4 equals the measured number at the digits printed; the range from low to high includes it.
By their numbers in this assay, from the lowest: compounds 4, 1, 3 and 2 (each within the scatter of the next, the first and the last beyond it).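

With the free amine in place of the carbamate, benzylamino in place of methoxy on the carbonyl carbon gives a 2.1-fold lower number from compound 3 to compound 4 (0.33 log units; beyond the scatter) in this assay, so this change now reads the same at both amine ends: the same change on two cores in this assay, a 2.2-fold higher number (0.34 log units; beyond the scatter) from compound 1 to compound 2 and a 2.1-fold higher number (0.33 log units; beyond the scatter) from compound 4 to compound 3, 1.0-fold (0.01 log units) apart, within the scatter of two such steps.

With benzylamino on the carbonyl carbon, hydrogen in place of tert-butoxycarbonyl on the amine nitrogen gives a 1.2-fold lower number from compound 1 to compound 4 (0.08 log units; within the scatter) and thus repeats, on a second core, the flat result seen with methoxy: the same change on two cores in this assay, a 1.2-fold lower number (0.09 log units; within the scatter) from compound 2 to compound 3 and a 1.2-fold lower number (0.08 log units; within the scatter) from compound 1 to compound 4, 1.0-fold (0.01 log units) apart, within the scatter of two such steps.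

Across the four compounds, the two changes therefore read as independent of each other, and the only single-change steps beyond the scatter are those on the carbonyl carbon.

The compounds shown do not separate the aromatic ring from the amide hydrogen, which enter together with benzylamino; methylamino or a carboxylic acid on the same carbonyl carbon would begin to do so. They also leave open whether the flat reading at the amine end would hold for a longer chain or for an amine carrying a small acyl group such as acetyl.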